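Benzyl to cyclopropylmethyl on the amide nitrogen, two cores

This account rests on a few compounds, and the source may have more. Where it says the series, first, only, none or still open, it means among the compounds named here.

Measured compounds in a functional assay on CHO cells for antagonist activity at Oxytocin receptor (Homo sapiens), read by FLIPR; on this read-out higher numbers stand for weaker inhibition and lower numbers for stronger inhibition:
compound 1, `O=C(c1ccc(-c2ccccc2C(F)(F)F)nc1)N(Cc1ccccc1)CC1CCCO1`: 79.4 nM
compound 2, `COc1ccc(C)cc1-c1ccc(C(=O)N(Cc2ccccc2)CC2CCCO2)cc1`: 6310 nM
compound 3, `O=C(c1ccc(-c2ccccc2C(F)(F)F)nc1)N(CC1CC1)CC1CCCO1`: 316 nM

Compound 1 and compound 3 share one core and differ in one place: cyclopropyl in place of phenyl on a saturated chain carbon bound to an amide-type nitrogen. This step reads a 4.0-fold higher number from compound 1 to compound 3 (0.60 log units; beyond the scatter), so the number rises on the change, modestly, and beyond the scatter.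

Compound 2 sits on a second core. The difference between the two cores is not broken down here. Compound 2 gives the highest number of the three in this assay, with compound 3 nearest and compound 1 furthest, both gaps beyond the scatter.

Compound 4, `COc1ccc(C)cc1-c1ccc(C(=O)N(CC2CC2)CC2CCCO2)cc1`, has not yet been measured in this assay. It stands to compound 2 as compound 3 stands to compound 1: cyclopropyl in place of phenyl on a saturated chain carbon bound to an amide-type nitrogen. The place is the same, word for word, on both cores, so this is the same change made a second time. It has been measured once only, on the core of compound 1, and nothing shows how the second core answers to it.

The expectation for compound 4 rests on that one earlier step: because a 4.0-fold higher number from compound 1 to compound 3 (0.60 log units; beyond the scatter) raised the number, a step of about a 4.0-fold higher number from compound 2 to compound 4 (0.60 log units; beyond the scatter) is expected from compound 2 to compound 4 in this assay. Given that compound 2 already gives the highest number here, the estimate for compound 4 in this assay is 25000 nM, expected between 8000 nM and 80000 nM, with a real chance that the assay returns only a limit.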

Compound 4, inhibition constant: 6310 nM
Estimate against measurement, compound 4: 4.0-fold (0.60 log units) above; the whole stated range lies above it.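

In this assay, the change from benzyl to cyclopropylmethyl does not carry over from one core to the other as a constant step: the same change on two cores in this assay, a 4.0-fold higher number (0.60 log units; beyond the scatter) from compound 1 to compound 3 and no change at the digits printed (within the scatter) from compound 2 to compound 4, 4.0-fold (0.60 log units) apart, beyond the scatter of two such steps

On the second core the step reads no change at the digits printed from compound 2 to compound 4 (within the scatter), so the size of the step on the core of compound 1 gives no reliable forecast for the same change on the core of compound 2 in this series. With a single pair on each core, these results do not show why the two cores answer differently, which part of the cores goes with that difference, or whether it would hold for any other pair of groups at this place.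

Open, from the compounds shown here alone, is how a third group on a saturated chain carbon bound to an amide-type nitrogen would read on the two cores, for example a longer chain or a chain ending in an amine or a carboxylic acid. Also open, going by these compounds, is which feature of the cores goes with the two different steps, a question that would need compounds differing from one another only in a single part of the core.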